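The source may hold more compounds than are shown below. What is called first, only, known or untested is meant among the compounds shown, and "the series" means these compounds.

Compound 1 `CCCCCCCCNC(=O)[C@@H](NC(=O)c1cc2ccccc2o1)[C@@H](C)O` and compound 2 `C/C=C/C=C/C(=O)N[C@H](C(=O)NCCCCCCCC)[C@@H](C)O` share the hydroxylated amide core and differ only at the acyl carbonyl. In a functional assay on SiHa cells (Homo sapiens) for cytotoxicity, read by MTT assay, with a stated time of 48 h (on this read-out lower numbers stand for stronger inhibition and higher numbers for weaker inhibition), compound 1 gives 66500 nM, and compound 2 gives 123000 nM. The step of a 1.8-fold higher number from compound 1 to compound 2 (0.27 log units; within the scatter) is within scatter, so on the two numbers at hand compound 2 stands at the higher end without being separable from compound 1.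

Compound 3 `C/C=C/C=C/C(=O)N[C@H](C(=O)NCCCCCCCCCCCCCCCCCC)[C@@H](C)O` keeps the acyl group of compound 2 and alters the amide chain: decyl in place of hydrogen on a saturated chain carbon, eight bonds along the chain from an amide-type nitrogen. Going by the values given here, no measured step touches this part of the molecule; the only step seen concerns the carbonyl substituent and says nothing about the chain. With nothing to anchor a direction, the step of a 1.1-fold lower number from compound 2 to compound 3 (0.05 log units; within the scatter) is expected to stay within scatter, and the estimate is wide. Compound 3 is expected to give about 110000 nM in this assay, between 30000 nM and 400000 nM.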

Compound 3, half-maximal inhibitory concentration: > 200000 nM
Compound 3: no number, only a limit; the forecaster's own chance of this, stated with the estimate: 30%; middle value at least 1.8-fold (0.25 log units) from the limit.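

The chain position now has a reading of its own: decyl in place of hydrogen on a saturated chain carbon, eight bonds along the chain from an amide-type nitrogen, gives an at least 1.6-fold higher number from compound 2 to compound 3 (0.21 log units; that floor lies within the scatter) in this assay. Compound 3 gives > 200000 nM, which is a limit of the assay and not a number. The added chain brings no lower number on this read-out, but the step has only a floor, so its true size cannot be read and compound 3 is not separated from compound 2: the limit of > 200000 nM in this assay, at which 1 of the 3 values shown sits.

Still open, as far as these compounds go, is how the number responds at this position to a shorter chain, or to a chain ending in an amine or a carboxylic acid. Also open, from the compounds shown here alone, is whether decyl at this place acts the same way when the acyl group is the 1-benzofuran-2-yl of compound 1.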